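A few compounds are considered here, and "the series" means these few. Any claim that something is new, unique, unknown or untested is made for them only; others in the source may bear on it.

Measured in a functional assay on DU-145 cells (Homo sapiens) for inhibition, read by trypan blue exclusion, with a stated time of 96 h; a lower number here means a stronger inhibitor of growth, a higher number a weaker inhibitor of growth:
Compound 1 `COc1ccccc1/C=C(/SCc1ccc(C)cc1)C(=O)c1ccc(Cl)cc1` gives 10000 nM
Compound 2 `COc1ccccc1/C=C(/SCc1ccccc1F)C(=O)c1ccc(Cl)cc1` gives 10000 nM

Against compound 1, compound 2 stands level at 10000 nM and has no other measured neighbour. The next compound to be tested is compound 3 `COc1ccccc1/C=C(/Sc1ccc(Br)cc1)C(=O)c1ccc(Cl)cc1`, which differs from compound 2 as follows: 4-bromophenyl in place of 2-fluorobenzyl on a sulfur. In words, 4-bromophenyl takes the place of 2-fluorobenzyl on a sulfur whose other neighbour is a double-bonded chain carbon.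

Among the measured compounds shown here, only one measured step bears on this change. That step, no change at the digits printed from compound 1 to compound 2 (within the scatter), swaps one ring group for another while keeping the saturated chain carbon bound to the sulfur. For the measured compounds named here, no measured step removes that carbon, so the evidence is thin and covers only part of the change. With that single step as the guide, no shift beyond the scatter is expected in this assay, and neither direction is favoured. The estimated step is no change at the digits printed from compound 2 to compound 3 (within the scatter) and it carries wide uncertainty. For compound 3 the expected value is 10000 nM within an estimated range of 3000 nM to 30000 nM.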

Compound 3, concentration for 50% growth inhibition: 10000 nM
The estimate for compound 3 equals the measured number at the digits printed, and the stated range covers the measured number.
By their numbers in this assay, from the lowest: compounds 1, 2 and 3 (each within the scatter of the next).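

In this assay, 4-bromophenyl in place of 2-fluorobenzyl on the sulfur gives no change at the digits printed from compound 2 to compound 3 (within the scatter) and so extends the picture beyond the earlier swap, which kept the saturated chain carbon on the sulfur: here that carbon is gone and the aromatic ring stands directly on the sulfur. Measured against the 4-methylbenzyl group, the same kind of replacement gives no change at the digits printed from compound 1 to compound 3 (within the scatter) and so points the same way, with the two benzyl groups and the 4-bromophenyl group not separated from one another in this assay. No measurement at hand accounts for this flat result.

From the compounds shown here alone, with only these three groups on the sulfur, all of them carrying one aromatic ring of carbon only, it remains open whether any group at this position can move the number at all. An amine, a carboxylic acid or a longer chain on this sulfur could still give a different reading, and the same question stands for changes elsewhere on the shared core.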